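The compounds below may be only part of what the source reports. "The series", "measured", "known", "first", "only" and "open" are said of these compounds alone.

Working notes on the series. In a functional assay on HeLa cells (Homo sapiens) for antiproliferative activity, read by sulforhodamine B assay, with a stated time of 48 h (on this read-out lower numbers stand for stronger inhibition of growth and higher numbers for weaker inhibition of growth), compound 1 `O=C(NCc1cn(Cc2ccc(F)cc2)nn1)c1cn(-c2ccccc2)nc1-c1ccccc1` gives 1600 nM. In this assay compound 2 `O=C(NCc1cn(Cc2ccc(C(F)(F)F)cc2)nn1)c1cn(-c2ccccc2)nc1-c1ccccc1` gives 1600 nM. In this assay compound 3 `O=C(NCc1cn(Cc2ccc(F)cc2)nn1)c1cn(-c2ccccc2)nc1-c1ccc(Cl)cc1` gives 2800 nM. Compound 3 lies within the scatter of both other numbers: a 1.8-fold higher number from compound 1 to compound 3 (0.24 log units; within the scatter), and its gap to compound 2 is of the same size. Compound 4 `O=C(NCc1cn(Cc2ccc(C(F)(F)F)cc2)nn1)c1cn(-c2ccccc2)nc1-c1ccc(Cl)cc1` differs from compound 3 by trifluoromethyl in place of fluoro on an aromatic carbon. The same change has been run once in the series, as no change at the digits printed from compound 1 to compound 2 (within the scatter), which bears directly on this step. A step beyond the scatter is therefore not expected in either direction. The expected step is no change at the digits printed from compound 3 to compound 4 (within the scatter). Compound 4 is expected to give 2800 nM in this assay, with a range from 1400 nM to 5600 nM.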

Compound 4, concentration for 50% growth inhibition: 1900 nM
Compound 4: middle estimate off by 1.5-fold (0.17 log units), on the high side, within the range that was stated.
By their numbers in this assay, from the lowest: compounds 1, 2, 4 and 3 (each within the scatter of the next).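

In this assay the change from 4-fluorobenzyl to 4-(trifluoromethyl)benzyl now stands on a second core, as a 1.5-fold lower number from compound 3 to compound 4 (0.17 log units; within the scatter), and the two readings agree: the same change on two cores in this assay, no change at the digits printed (within the scatter) from compound 1 to compound 2 and a 1.5-fold lower number (0.17 log units; within the scatter) from compound 3 to compound 4, 1.5-fold (0.17 log units) apart, within the scatter of two such steps. Chloro in place of hydrogen also now stands on a second core, as a 1.2-fold higher number from compound 2 to compound 4 (0.07 log units; within the scatter), and again the two readings agree: the same change on two cores in this assay, a 1.8-fold higher number (0.24 log units; within the scatter) from compound 1 to compound 3 and a 1.2-fold higher number (0.07 log units; within the scatter) from compound 2 to compound 4, 1.5-fold (0.17 log units) apart, within the scatter of two such steps. Neither change moves the number beyond the scatter on either core.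

Open, on these data alone, is whether an amine or a carboxylic acid in place of the trifluoromethyl would give a step beyond the scatter in this assay.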